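Sulfonyl aryl substituent change: methoxy to cyano

A few compounds are considered here, and "the series" means these few. Any claim that something is new, unique, unknown or untested is made for them only; others in the source may bear on it.

Within the data shown here, the three measured members share one core and differ only in the aryl group on the sulfonyl sulfur. Compound 1 `CC1CCN(c2c(S(=O)(=O)c3ccc(F)c(Cl)c3)cnc3cc(F)ccc23)CC1` carries a 3-chloro-4-fluorophenyl there; in an assay on isolated protein for displacement of a labelled ligand from metabotropic glutamate receptor 5 (Homo sapiens), with a stated time of 60 min, tested at 1 uM (on this read-out lower numbers stand for less inhibition and higher numbers for more inhibition at the one concentration tested (going by the name of the read-out)), compound 1 gives 94%. Compound 2 `COc1ccc(S(=O)(=O)c2cnc3cc(F)ccc3c2N2CCC(C)CC2)cc1` carries a 4-methoxyphenyl and gives 90%, a step of a number 4 percentage points lower from compound 1 to compound 2 (within the scatter). Compound 3 `COc1cccc(S(=O)(=O)c2cnc3cc(F)ccc3c2N2CCC(C)CC2)c1` carries a 3-methoxyphenyl and gives 90%; the step is a number 4 percentage points lower from compound 1 to compound 3 (within the scatter), and between the two methoxy isomers no change at the digits printed from compound 2 to compound 3 (within the scatter). Compound 3 thus stands level with compound 2, and every step among the three remains inside the scatter, so no ordering can be read from these numbers.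

Compound 4 `CC1CCN(c2c(S(=O)(=O)c3cccc(C#N)c3)cnc3cc(F)ccc23)CC1` follows from compound 3 by cyano in place of methoxy on an aromatic carbon. Among the measured compounds shown here, the steps that bear on this are the aryl substituent changes already seen: a number 4 percentage points lower from compound 1 to compound 3 (within the scatter) and no change at the digits printed from compound 2 to compound 3 (within the scatter), neither of which left the scatter. On that basis the expected step is a number 2 percentage points lower from compound 3 to compound 4 (within the scatter), that is, no movement beyond the scatter in this assay. The estimate for compound 4 is therefore 88%, with a range from 74% to 96%.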

Compound 4, a percentage reported as inhibition, at one concentration (the size of the read-out at that concentration, not a potency): 92%
Beside the measured number, compound 4's estimate is 4 percentage points below it; measured number inside the range.
By their numbers in this assay, from the lowest: compounds 2, 3, 4 and 1 (each within the scatter of the next).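

In this assay the cyano group joins the aryl substituents already seen on the sulfonyl sulfur: cyano in place of methoxy on an aromatic carbon gives a number 2 percentage points higher from compound 3 to compound 4 (within the scatter) and leaves the result level with the methoxy isomers, while the comparison with the other methoxy isomer reads a number 2 percentage points higher from compound 2 to compound 4 (within the scatter) and the comparison with the halogenated aryl group reads a number 2 percentage points lower from compound 1 to compound 4 (within the scatter) in this series. At this place, meta to a large group, methoxy and cyano therefore cannot be told apart at the one concentration tested, and the four aryl groups shown form no readable order. Nothing at hand offers a reason for this flat result.

Still open, from the compounds shown here alone, is whether an amine, a carboxylic acid or a longer chain at this place on the ring would produce a step beyond the scatter in this assay and in which direction it would go. Also open, going by these compounds, are how the 4-cyanophenyl group compares with the 3-cyanophenyl group of compound 4 and whether full concentration-response curves would separate these four compounds.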